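Benzimidazole Thioethers: Butyl Chain Exchanged for Pyridinylmethyl

A few compounds are considered here, and "the series" means these few. Any claim that something is new, unique, unknown or untested is made for them only; others in the source may bear on it.

The study gathered two measured compounds in an assay on isolated protein for inhibition of Gonadotropin-releasing hormone receptor (Homo sapiens); a lower number here means a stronger inhibitor, a higher number a weaker inhibitor. Compound 1, with structure `COc1ccccc1CSc1nc2cc(NC(=O)C3CC3)ccc2n1C(C)C`, gives 2100 nM in this assay. Compound 2, with structure `CCCCn1c(SCc2cc([N+](=O)[O-])ccc2OC)nc2cc(NC(=O)NC(C)(C)C)ccc21`, gives 23 nM in this assay, the lower of the two numbers, and its gap to compound 1 lies well beyond the usual scatter. Within the data shown here, the two differ in several places at once, so no single-point step can be drawn between them; their two values simply show that compound 2 is the stronger inhibitor of the pair.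

Compound 3, with structure `COc1ccc([N+](=O)[O-])cc1CSc1nc2cc(NC(=O)NC(C)(C)C)ccc2n1Cc1ccncc1`, keeps the core of compound 2 and changes only the chain on the aromatic nitrogen: pyridin-4-yl in place of propyl on a saturated chain carbon bound to an aromatic nitrogen. Among the measured compounds shown here, no measured pair in this set isolates such a change, so the data give no direct guide. With compound 2 standing at 23 nM in this assay, the expectation is that compound 3 stays close to it, the estimated step being a 1.2-fold lower number from compound 2 to compound 3 (0.06 log units; within the scatter), within or near the scatter and not clearly in either direction. Compound 3 is therefore estimated at 20 nM in this assay, within a range from 6 nM to 70 nM.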

Compound 3, half-maximal inhibitory concentration: 47 nM
The estimate for compound 3 lay 2.4-fold (0.37 log units) below the measured number; measured number inside the range.
By their numbers in this assay, from the lowest: compound 2; then compound 3; then compound 1.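

Among these compounds, this is the first one-place comparison in the set, and it bears directly on the chain on the aromatic nitrogen: in this assay, pyridin-4-yl in place of propyl on a saturated chain carbon bound to an aromatic nitrogen gives a 2.0-fold higher number from compound 2 to compound 3 (0.31 log units; beyond the scatter), a modest step just beyond the scatter. The position therefore accepts an aromatic ring carrying a hydrogen-bond acceptor in place of an open chain, at only this small cost in the measured number. No measurement of any property of these compounds accounts for the rise.

Going by these compounds, a benzyl group at the same place would separate the contribution of the ring from that of its nitrogen, and how a pyridin-3-yl group, an amine or a longer chain such as hexyl would compare with the butyl chain remains open. On these data alone, whether the same exchange would produce a step of similar size on the core of compound 1, with its different amide, also remains open.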